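The source may hold more compounds than are shown below. What is called first, only, known or untested is meant among the compounds shown, and "the series" means these compounds.

Three compounds that share one core and differ only in a chain on an oxygen give a first picture. In a physicochemical assay for lipophilicity, read by HPLC, in phosphate buffer, measured as octanol-water partition, at pH 7.4, tested at 100 uM (a lower number here means a more polar compound, a higher number a more lipophilic compound), compound 1 `CCOc1ccc(-c2cccc(CNc3ccc(OCC(=O)O)c(F)c3)c2)c(C)c1` gives 2.83, compound 2 `CCCOc1ccc(-c2cccc(CNc3ccc(OCC(=O)O)c(F)c3)c2)c(C)c1` gives 3.37, and compound 3 `COCCOc1ccc(-c2cccc(CNc3ccc(OCC(=O)O)c(F)c3)c2)c(C)c1` gives 2.23, the lowest of the three numbers.

Compound 4 `Cc1cc(OCCO)ccc1-c1cccc(CNc2ccc(OCC(=O)O)c(F)c2)c1` differs from compound 3 at the end of that chain: hydrogen in place of methyl on an oxygen on a saturated carbon. This turns 2-methoxyethyl into 2-hydroxyethyl. Among the measured compounds shown here, no measured step makes this exact change, so the evidence is indirect. Read backwards, the gain of a methyl in a number 0.54 log units higher from compound 1 to compound 2 (beyond the scatter) suggests that losing a methyl lowers the number. The other two steps on this chain, a number 0.60 log units lower from compound 1 to compound 3 (beyond the scatter) and a number 1.14 log units lower from compound 2 to compound 3 (beyond the scatter), show that methoxy in the chain goes with lower numbers, and that small edits here move this assay beyond the scatter.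

A modest fall is therefore expected, and the estimated change is a number 0.43 log units lower from compound 3 to compound 4 (beyond the scatter). The estimated value for compound 4 is 1.8, with an expected range from 1.4 to 2.2.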

Compound 4, distribution coefficient: 1.65
The estimate for compound 4 lay 0.15 log units above the measured number, and the stated range covers the measured number.
By their numbers in this assay, from the lowest: compound 4; then compound 3; then compound 1; then compound 2.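

The change from 2-methoxyethyl to 2-hydroxyethyl gives a number 0.58 log units lower from compound 3 to compound 4 (beyond the scatter) in this assay and so shows that the far end of this chain still matters: removing one methyl from the oxygen moves the number on its own. With a number 1.18 log units lower from compound 1 to compound 4 (beyond the scatter) and a number 1.72 log units lower from compound 2 to compound 4 (beyond the scatter) as well, compound 4 stands lowest of the four, and both of these steps are large. Hydroxy now joins hydrogen, methyl and methoxy at the same chain carbon, and of these four it goes with the lowest number.

From the compounds shown here alone, whether an amine or a carboxylic acid at the end of this chain, or a longer chain ending in hydroxy, would fall further remains open. Nothing measured here gives a reason for these shifts.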